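The compounds below may be only part of what the source reports. "The series", "measured", "known", "first", "only" and "open" are said of these compounds alone.

Compound 1 `Cc1cnc(N)nc1-c1ccccc1`: 34%
Compound 2 `CCOC(=O)Nc1nccc(-c2ccncc2)n1`: 31%
Compound 3 `Cc1ncc(-c2ccccc2)c(C(C)(C)C)n1`: 22%

In a functional assay on the whole organism for inhibition, with Rattus norvegicus as the target, with stated times of 1 h and 3.5 h, at a dose of 100 mg/kg by the oral route (on this read-out higher numbers stand for more inhibition at the one dose given (going by the name of the read-out) and lower numbers for less inhibition), compound 3 gives 22%, the lowest of the three numbers. Its nearest neighbour is compound 2 at 31%, a gap that lies within the scatter, so the two cannot be ordered. Compound 1 at 34% stands further off, beyond the scatter.

Compound 4 `CC(C)(C)c1nc(NC#N)ncc1-c1ccccc1` shares the core of compound 3 and differs in one place: cyanoamino in place of methyl on an aromatic carbon. Going by the values given here, no pair of measured compounds shows this same change, so the size of its step has to be judged from the three numbers alone. Compound 1 and compound 2 both carry a nitrogen-bound group between two ring nitrogen atoms and both sit somewhat higher than compound 3, which points, weakly, upward. Compound 4 is therefore expected to give 30%, with a range from 12% to 48%. That estimate means an expected step of a number 8 percentage points higher from compound 3 to compound 4 (within the scatter), a rise of a size that stays within the scatter rather than one clearly beyond it.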

Compound 4, a percentage reported as inhibition, in the whole organism at one dose (the size of the read-out at that dose, not a potency): < 5%
Compound 4: no number, only a limit; the forecaster's own chance of this, stated with the estimate: 0%; middle value at least 25 percentage points from the limit.
By their numbers in this assay, from the lowest: compounds 3, 2 and 1 (each within the scatter of the next, the first and the last beyond it). At a limit, below all of these: compound 4.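

In this assay, cyanoamino in place of methyl on an aromatic carbon between two ring nitrogen atoms gives the first step read at this position, a number at least 17 percentage points lower from compound 3 to compound 4 (beyond the scatter). Compound 4 gives < 5%, which is a limit of the assay and not a number: the limit of < 5% in this assay, at which 1 of the 4 values shown sits. Going by these compounds alone, the earlier compounds included no pair differing in one place, so this is the first sign that a change at this position can lower the read-out, and the true size of the step remains known only as a bound.

On these data alone, whether other groups at this position on the shared core, such as an amine, a methoxy group or a carboxylic acid, would keep the inhibition stays open. So does whether the same change would act alike on another core, as no second pair shows it.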